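Compound 4: methyl in place of difluoromethyl

This account rests on a few compounds, and the source may have more. Where it says the series, first, only, none or still open, it means among the compounds named here.

- compound 1 `Cc1c(C(F)F)nnc2sc(C(=O)NC3CN(c4ncc(C(F)(F)F)cn4)C3)c(N)c12`: 0.017
- compound 2 `Cc1c(CF)nnc2sc(C(=O)NC3CN(c4ncc(C(F)(F)F)cn4)C3)c(N)c12`: 0.034
- compound 3 `COc1nnc2sc(C(=O)NC3CN(c4ncc(C(F)(F)F)cn4)C3)c(N)c2c1C`: 0.018

In an ADME assay on a cell-free system (plasma, Rattus norvegicus) for protein binding (on this read-out higher numbers stand for a larger free fraction and lower numbers for a smaller free fraction), compound 1 gives 0.017 and does not stand apart from the other two measured compounds, since none of the steps among the three leaves the scatter. Compound 4 `Cc1nnc2sc(C(=O)NC3CN(c4ncc(C(F)(F)F)cn4)C3)c(N)c2c1C` has not yet been measured. Its difference from compound 1 is methyl in place of difluoromethyl on an aromatic carbon.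

The closest measured change is hydrogen in place of fluoro on that group, which gave a 2.0-fold higher number from compound 1 to compound 2 (0.30 log units; within the scatter). Methoxy in place of difluoromethyl gave a 1.1-fold higher number from compound 1 to compound 3 (0.02 log units; within the scatter), and methoxy in place of fluoromethyl gave a 1.9-fold lower number from compound 2 to compound 3 (0.28 log units; within the scatter). Within the data shown here, no measured step replaces difluoromethyl with methyl directly, so the expectation rests on these three. A small upward move is expected, of about the size of the first step and not clearly beyond the scatter.

The estimated step is a 1.9-fold higher number from compound 1 to compound 4 (0.27 log units; within the scatter).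

For compound 4 the expected value is 0.032, with an estimated range of 0.017 to 0.06.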

Compound 4, unbound fraction: 0.028
Beside the measured number, compound 4's estimate is 1.1-fold (0.06 log units) above it, within the range that was stated.
By their numbers in this assay, from the lowest: compounds 1, 3, 4 and 2 (each within the scatter of the next).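

In this assay the direct exchange of difluoromethyl for methyl on this aromatic carbon next to the ring nitrogen gives a 1.6-fold higher number from compound 1 to compound 4 (0.22 log units; within the scatter) and so removal of both fluorine atoms stays inside the scatter. Methyl in place of methoxy gives a 1.6-fold higher number from compound 3 to compound 4 (0.19 log units; within the scatter) and hydrogen in place of fluoro on the fluoromethyl group gives a 1.2-fold lower number from compound 2 to compound 4 (0.08 log units; within the scatter) and so difluoromethyl, fluoromethyl, methoxy and methyl cannot be told apart at this position. Nothing measured here accounts for how closely these four compounds lie.

On these data alone, whether an amine, a carboxylic acid or a longer chain on this carbon would move the number in this assay beyond the scatter remains open. The compounds shown also leave open whether the same holds once the methyl group ortho to this position is changed.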